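A few compounds are considered here, and "the series" means these few. Any claim that something is new, unique, unknown or untested is made for them only; others in the source may bear on it.

Compound 1 `CCN(CC)C(=O)CC1CCc2cc(OC)c(OC)cc21`: 37.7%
Compound 2 `COc1cc2c(cc1OC)C(CC(=O)NC(C)C)CC2`: 30.4%
Compound 3 `CCCCNC(=O)CC1CCc2cc(OC)c(OC)cc21`: 27.5%

All three were tested in a functional assay on the whole organism (strain Wistar) for inhibition, with Rattus norvegicus as the target, read by paw edema, with stated times of 60 min and 3 h, at a dose of 100 mg/kg by the oral route; a higher number here means more inhibition at the dose given (going by the name of the read-out), a lower number less inhibition. Compound 1 stands highest of the three numbers; one step away from it is a number 7.3 percentage points lower from compound 1 to compound 2 (within the scatter), the other is a number 10.2 percentage points lower from compound 1 to compound 3 (beyond the scatter), and only the second of these goes beyond the scatter. The remaining step is a number 2.9 percentage points lower from compound 2 to compound 3 (within the scatter).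

Compound 4 `COc1cc2c(cc1OC)C(CC(=O)NCc1ccccc1)CC2` has not yet been measured. It differs from compound 1 in a single place: benzylamino in place of diethylamino on a carbonyl carbon. The two measured steps that bear on this change are the ones in which diethylamino also leaves the carbonyl carbon and a single group on the amide-type nitrogen takes its place: a number 7.3 percentage points lower from compound 1 to compound 2 (within the scatter) and a number 10.2 percentage points lower from compound 1 to compound 3 (beyond the scatter). Both point downward, one within and one beyond the scatter. A modest downward step is therefore expected here too, a number 9.7 percentage points lower from compound 1 to compound 4 (within the scatter). Compound 4 is estimated to give 28% in this assay, with a range from 14% to 42%.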

Compound 4, a percentage reported as inhibition, in the whole organism at one dose (the size of the read-out at that dose, not a potency): 14.5%
Compound 4: middle estimate off by 13.5 percentage points, on the high side; low and high end bracket the measured number.
By their numbers in this assay, from the lowest: compound 4; then compounds 3, 2 and 1 (each within the scatter of the next, the first and the last beyond it).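

In this assay, replacing diethylamino with benzylamino on the carbonyl carbon gives a larger loss than the earlier replacements (a number 23.2 percentage points lower from compound 1 to compound 4 (beyond the scatter)), and compound 4 stands lowest of the four. The loss is not explained simply by diethylamino leaving, since benzyl also falls short of the other single groups on the amide-type nitrogen (a number 15.9 percentage points lower from compound 2 to compound 4 (beyond the scatter); a number 13 percentage points lower from compound 3 to compound 4 (beyond the scatter)), and phenyl in place of propyl accounts for the second of these steps. So the identity of the entering group matters at this position, but nothing measured here gives the reason for the drop.

A cyclohexylmethylamino group would test whether the drop depends on the aromatic ring, while phenethylamino would test the effect of a longer chain before that ring. On these data alone, it also remains open whether piperidine on the carbonyl carbon, with the nitrogen held in a ring, would match compound 1.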